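Notes on the aryl amine variation, compounds 1 to 3

The source may report more compounds than this note shows. Statements on the series, on what has been measured and on what is new or still open speak of the compounds shown alone.

Measured compounds:
- compound 1, `COc1cc(NC(=O)Nc2cc(Nc3cccc(C(C)(C)C)c3)ncn2)cc(OC)c1`: 13.1%
- compound 2, `COc1cc(NC(=O)Nc2cc(Nc3cc(Br)ccc3OC)ncn2)cc(OC)c1`: 43.5%

In a functional assay on NCI-H520 cells (Homo sapiens) for inhibition, read by MTT assay, with a stated time of 48 h, tested at 10 uM (a lower number here means less inhibition, a higher number more inhibition at the concentration tested (going by the name of the read-out)), compound 2 stands highest of the two numbers shown; its nearest neighbour is compound 1, whose value sits beyond the scatter below it. Among the measured compounds shown here, the one measured step in this assay, a number 30.4 percentage points higher from compound 1 to compound 2 (beyond the scatter), was large and came from exchanging the aryl group on the nitrogen on the aromatic ring.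

Compound 3, `COc1cc(NC(=O)Nc2cc(Nc3cc(C)cc(F)c3)ncn2)cc(OC)c1`, is not yet measured. It differs from compound 2 as follows: 3-fluoro-5-methylphenyl in place of 5-bromo-2-methoxyphenyl on a nitrogen on an aromatic ring

For the measured compounds named here, only the step from compound 1 to compound 2 bears on this change, and it shows that this aryl group can move the read-out well beyond the scatter. Which way the new group goes is not settled by one step, so a moderate downward step is expected, with compound 2 as the reference: a number 15.5 percentage points lower from compound 2 to compound 3 (beyond the scatter). Compound 3 is therefore estimated at 28%, within 10% to 48%.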

Compound 3, a percentage reported as inhibition, at one concentration (the size of the read-out at that concentration, not a potency): 24.5%
Estimate against measurement, compound 3: 3.5 percentage points above, within the range that was stated.
By their numbers in this assay, from the lowest: compound 1; then compound 3; then compound 2.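

In this assay, 3-fluoro-5-methylphenyl in place of 5-bromo-2-methoxyphenyl on the nitrogen gives a number 19 percentage points lower from compound 2 to compound 3 (beyond the scatter), so a second exchange at this position also moves the read-out beyond the scatter. Set against 3-(tert-butyl)phenyl, the same group gives a number 11.4 percentage points higher from compound 1 to compound 3 (beyond the scatter), which places the three aryl groups at three separate levels, with 5-bromo-2-methoxyphenyl still the highest of them. No supporting data on hand bear on this order.

Each exchange alters more than one substituent at once, so the separate contributions of the bromine, methoxy, fluorine, methyl and tert-butyl groups cannot be told apart. On these data alone, it also remains open where an unsubstituted phenyl, or a phenyl carrying an amine or a carboxylic acid, would fall at this nitrogen.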